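A few compounds are considered here, and "the series" means these few. Any claim that something is new, unique, unknown or untested is made for them only; others in the source may bear on it.

Working notes on the selenium series, followed in a functional assay on CCRF-CEM cells (Homo sapiens) for cytotoxicity, read by MTT assay, with a stated time of 72 h; on this read-out higher numbers stand for weaker inhibition of growth and lower numbers for stronger inhibition of growth. Compound 1 `COc1ccc(CNc2nc([Se]C)nc3ccccc23)cc1` returns only a limit in this assay, > 100000 nM, not a number. For the measured compounds named here, compound 2 `CCCCC[Se]c1nc(NCc2ccccc2)c2ccccc2n1` gives 72500 nM in this assay and so stands as the only number recorded. The other entry, that of compound 1, is a limit, (the limit of > 100000 nM in this assay, at which 1 of the 2 values shown sits). Compound 3 `C[Se]c1nc(NCc2ccccc2)c2ccccc2n1` is not yet measured. It differs from compound 2 by hydrogen in place of butyl on a saturated chain carbon bound to a selenium atom, which read one bond further out is pentyl to methyl. Going by the values given here, no step between measured compounds is available to calibrate this change. Compound 1 likewise carries methyl on the selenium and sits at the limit, but it differs from compound 3 elsewhere too, so the two values can only be set side by side. The step is expected to weaken growth inhibition, a 1.5-fold higher number from compound 2 to compound 3 (0.18 log units; within the scatter), with a fair chance that only a limit is returned. Compound 3 is estimated at 110000 nM in this assay, between 40000 nM and 300000 nM.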

Compound 3, concentration for total growth inhibition: 61600 nM
Beside the measured number, compound 3's estimate is 1.8-fold (0.25 log units) above it, and the stated range covers the measured number.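

Hydrogen in place of butyl on a saturated chain carbon bound to a selenium atom gives a 1.2-fold lower number from compound 2 to compound 3 (0.07 log units; within the scatter) in this assay and so, for this pair, pentyl and methyl at this place cannot be told apart. Hydrogen in place of methoxy on an aromatic carbon gives an at least 1.6-fold lower number from compound 1 to compound 3 (0.21 log units; that floor lies within the scatter) and offers a first reading at a second place, though only its floor can be read. Compound 1 remains a limit and not a number: the limit of > 100000 nM in this assay, at which 1 of the 3 values shown sits.

The compounds shown leave open whether a chain longer than pentyl or an amine at the end of the chain on selenium would move the number beyond the scatter in this assay. They also leave open what sulfur in place of the selenium atom would give on the same core.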